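The source may report more compounds than this note shows. Statements on the series, on what has been measured and on what is new or still open speak of the compounds shown alone.

Values in an ADME assay on MT4 cells (Homo sapiens) for activation, read by MTT assay (on this read-out higher numbers stand for lower toxicity in this test and lower numbers for higher toxicity in this test), each of them a limit:
- compound 1 `CCCSc1nc(Cc2c(F)cccc2Cl)c(C)c(=O)[nH]1` gives > 76000 nM
- compound 2 `CCCSc1nc(C(C)c2c(F)cccc2Cl)cc(=O)[nH]1` gives > 75000 nM
- compound 3 `CCCSc1nc(C(C)c2c(F)cccc2Cl)c(C)c(=O)[nH]1` gives > 1500 nM

Compound 3 stands only at a limit, and it is not a measured number. Compound 4 `Cc1c(C(C)c2c(F)cccc2Cl)nc(SC2CCCC2)[nH]c1=O` has cyclopentyl in place of propyl on a sulfur. The chain on the sulfur has not been varied among the measured compounds, and the two measured steps are both methyl changes elsewhere. These are a step that the two limits leave unreadable from compound 1 to compound 3 and a step that the two limits leave unreadable from compound 2 to compound 3. Neither gives a size or direction to carry over, so the expectation is only loosely held. The expected step is a step that the limit leaves unreadable from compound 3 to compound 4, and it is tentative. For compound 4 the estimated value is 25000 nM, with an expected range of 4000 nM to 100000 nM.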

Compound 4, half-maximal cytotoxic concentration: > 15000 nM
Compound 4: a limit, no number; the forecaster's own chance of this, stated with the estimate: 65%; the middle value does not contradict the limit.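

Compound 3 is only a limit, > 1500 nM. Among the compounds shown here, compound 4 is likewise only a limit, > 15000 nM, so no step between the two can be read. As far as these compounds go, the size and direction of any effect of cyclopentyl in place of propyl on the sulfur in this assay remain open.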